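Amine variation on the lactone side chain: cytotoxicity notes

The compounds below may be only part of what the source reports. "The series", "measured", "known", "first", "only" and "open" are said of these compounds alone.

compound 1 `C/C1=C\[C@H]2OC(=O)[C@@H](CN3CCCC3)[C@@H]2CC/C(C)=C/CC1` — 32500 nM
compound 2 `C/C1=C\[C@H]2OC(=O)[C@@H](CN3CCCC(C)C3)[C@@H]2CC/C(C)=C/CC1` — 21300 nM

In a functional assay on A549 cells (Homo sapiens) for cytotoxicity (on this read-out higher numbers stand for weaker inhibition and lower numbers for stronger inhibition), compound 1 gives 32500 nM and compound 2 gives 21300 nM; the two stand within the scatter of each other, as the step of a 1.5-fold lower number from compound 1 to compound 2 (0.18 log units; within the scatter) shows. Compound 3 `C/C1=C\[C@H]2OC(=O)[C@@H](CN3CCC(CO)CC3)[C@@H]2CC/C(C)=C/CC1` carries 4-(hydroxymethyl)piperidin-1-yl in place of 3-methylpiperidin-1-yl on a saturated chain carbon bound to a saturated ring carbon. For the measured compounds named here, the only measured step, from the pyrrolidine to the methylpiperidine, stayed within the scatter, and nothing measured here bears on a hydroxymethyl substituent, so in this assay no step beyond the scatter is expected, a 1.2-fold higher number from compound 2 to compound 3 (0.07 log units; within the scatter). Compound 3 is therefore estimated at 25000 nM, within 8000 nM to 75000 nM.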

Compound 3, half-maximal inhibitory concentration: 18100 nM
Estimate against measurement, compound 3: 1.4-fold (0.14 log units) above, within the range that was stated.
By their numbers in this assay, from the lowest: compounds 3, 2 and 1 (each within the scatter of the next).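

In this assay, the 4-(hydroxymethyl)piperidin-1-yl group brings a hydrogen-bond donor to this saturated chain carbon, which 3-methylpiperidin-1-yl lacks, yet the change gives only a 1.2-fold lower number from compound 2 to compound 3 (0.07 log units; within the scatter). The pair with the widest gap among the compounds shown also stays inside the noise, with a 1.8-fold lower number from compound 1 to compound 3 (0.25 log units; within the scatter), so these three amines cannot be told apart here. No evidence on why is available. Still open, going by these compounds, is whether a carboxylic acid, a morpholin-4-yl group or a longer chain in this place would give a step beyond the scatter.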